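A few compounds are considered here, and "the series" means these few. Any claim that something is new, unique, unknown or untested is made for them only; others in the source may bear on it.

Series notes

compound 1 (`COc1ccc(Cn2ncc3c2NC(=O)CC(c2cccc(NC(=O)Nc4cccc(Cl)c4)c2)=N3)cc1`): 630 nM
compound 2 (`COc1ccc(Cn2ncc3c2NC(=O)CC(c2cccc(NC(=O)Nc4ccc(Cl)cc4)c2)=N3)cc1`): 580 nM
compound 3 (`COc1ccc(Cn2ncc3c2NC(=O)CC(c2cccc(NC(=O)Nc4cc(Cl)cc(Cl)c4)c2)=N3)cc1`): not yet measured

Within the data shown here, in a functional assay on U-937 cells (Homo sapiens) for inhibition, read by MTT assay, with a stated time of 24 h (on this read-out higher numbers stand for weaker inhibition of growth and lower numbers for stronger inhibition of growth), compound 2 stands at 580 nM and lies within the scatter of compound 1, its only measured neighbour. Neither compound can be ranked over the other on these numbers.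

The change from compound 2 to compound 3 is 3,5-dichlorophenyl in place of 4-chlorophenyl on an amide-type nitrogen and it falls on the same amide-type nitrogen. Among the measured compounds shown here, one measured step bears on it: a 1.1-fold lower number from compound 1 to compound 2 (0.04 log units; within the scatter) for 4-chlorophenyl in place of 3-chlorophenyl at that place, a step within the scatter. For the measured compounds named here, no measured compound carries 3,5-dichlorophenyl, and two values offer no pattern to extend, so this expectation rests on thin ground. Given the small size of that one step, no change beyond the scatter is expected in this assay in either direction. The expected step is a 1.2-fold lower number from compound 2 to compound 3 (0.06 log units; within the scatter) and no more than that is read into it. For compound 3 the estimate is 500 nM with an expected range from 200 nM to 1200 nM for repeated measurements.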

Compound 3, concentration for 50% growth inhibition: 6480 nM
For compound 3 the middle estimate is 13-fold (1.11 log units) below the measured one, and the stated range ends below it.
By their numbers in this assay, from the lowest: compounds 2 and 1 (each within the scatter of the next); then compound 3.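

In this assay the aryl group on the amide-type nitrogen turns out to be sensitive to substitution, which the two single-chloro compounds could not show, since their step lay within the scatter. Replacing 4-chlorophenyl with 3,5-dichlorophenyl gives an 11-fold higher number from compound 2 to compound 3 (1.05 log units; beyond the scatter) and adding one chloro in place of hydrogen on an aromatic carbon gives a 10-fold higher number from compound 1 to compound 3 (1.01 log units; beyond the scatter) so the two routes to the dichlorinated ring agree in direction and in size, and growth inhibition is clearly weaker with this ring. Nothing available explains this drop in growth inhibition.

The compounds shown leave open whether the drop follows from the second chloro as such or from the particular arrangement in 3,5-dichlorophenyl, a question that 3,4-dichlorophenyl on the same nitrogen would address. They also leave open how unsubstituted phenyl, or a ring carrying methoxy, a carboxylic acid or an amine in place of chloro, would stand in this assay against the single-chloro compounds.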